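A 4-chlorobenzyl group on the oxygen of compound 1

The source may hold more compounds than are shown below. What is called first, only, known or untested is meant among the compounds shown, and "the series" means these compounds.

In a functional assay on MCF7 cells (Homo sapiens) for inhibition, read by WST assay, with stated times of 72 h and 2 h (a higher number here means a weaker inhibitor, a lower number a stronger inhibitor), compound 1 `OC(c1cccs1)c1cc2ccccc2nc1Cl` gives 80600 nM. Compound 2 `Clc1nc2ccccc2cc1C(OCc1ccccc1)c1cccs1` gives 108000 nM, within the scatter of compound 1. Compound 3 `Fc1ccc(COC(c2cccs2)c2cc3ccccc3nc2Cl)cc1` gives 38400 nM, the lowest number of the three.

Compound 4 `Clc1ccc(COC(c2cccs2)c2cc3ccccc3nc2Cl)cc1` is unmeasured and differs from compound 1 by 4-chlorobenzyl in place of hydrogen on an oxygen on a saturated carbon, with 4-chlorobenzyl in place of hydrogen on an oxygen on a saturated carbon. Benzyl gave a 1.3-fold higher number from compound 1 to compound 2 (0.13 log units; within the scatter), and 4-fluorobenzyl gave a 2.1-fold lower number from compound 1 to compound 3 (0.32 log units; beyond the scatter). Fluoro in place of hydrogen gave a 2.8-fold lower number from compound 2 to compound 3 (0.45 log units; beyond the scatter). Among the measured compounds shown here, no measured compound carries chlorine, so a small downward step is expected in this assay, estimated as a 1.6-fold lower number from compound 1 to compound 4 (0.19 log units; within the scatter). Compound 4 is expected at 52000 nM, within an estimated range of 24000 nM to 110000 nM.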

Compound 4, half-maximal inhibitory concentration: 28300 nM
Compound 4: the middle estimate sits 1.8-fold (0.26 log units) above what was measured; low and high end bracket the measured number.
By their numbers in this assay, from the lowest: compounds 4 and 3 (each within the scatter of the next); then compounds 1 and 2 (each within the scatter of the next).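

In this assay, 4-chlorobenzyl on the oxygen moves the number beyond the scatter (a 2.8-fold lower number from compound 1 to compound 4 (0.45 log units; beyond the scatter)), and so does chloro in place of hydrogen on the benzyl group (a 3.8-fold lower number from compound 2 to compound 4 (0.58 log units; beyond the scatter)), so both halogen-bearing benzyl groups now do this while plain benzyl does not. Chloro in place of fluoro stays within the scatter (a 1.4-fold lower number from compound 3 to compound 4 (0.13 log units; within the scatter)), so this assay does not separate the two halogens. Nothing available here explains these steps. Going by these compounds, what an amine or a carboxylic acid on the benzyl group would do, or a longer chain in its place, stays open.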